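The compounds below may be only part of what the source reports. "The series", "measured", "known", "first", "only" and "open" are said of these compounds alone.

In a functional assay on SW 1116 cells (Homo sapiens) for cytotoxicity, read by MTT assay, with a stated time of 48 h (a lower number here means a stronger inhibitor, a higher number a weaker inhibitor), compound 1 `NNC(=O)CSc1nnc(-c2ccncc2)o1` gives 3260 nM as its result, while compound 2 `O=C(CSc1nnc(-c2ccncc2)o1)N/N=C/c1ccc(Br)cc1` gives 21300 nM and so holds the higher of the two numbers. That gap lies beyond the usual scatter of repeated measurements, which makes compound 2 the weaker inhibitor of this pair. Compound 3 `O=C(CSc1nnc(-c2ccncc2)o1)N/N=C/c1ccccc1F` has not been measured yet. Against compound 2 the change is 2-fluorophenyl in place of 4-bromophenyl on a carbon with a double bond to nitrogen in one place, with 2-fluorophenyl in place of 4-bromophenyl on a carbon with a double bond to nitrogen. The rest of the structure stays the same. For the measured compounds named here, no pair of measured compounds shows what a swap of this kind does, so any expectation here has to stay loose and the range has to be wide. The step expected is a 1.3-fold lower number from compound 2 to compound 3 (0.12 log units; within the scatter) and that is small, within the scatter, leaning slightly toward a lower number in this assay without a clear change in strength. The estimate for compound 3 is 16000 nM with an expected range from 5000 nM to 50000 nM once it is measured.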

Compound 3, half-maximal inhibitory concentration: 21500 nM
For compound 3 the middle estimate is 1.3-fold (0.13 log units) below the measured one, and the stated range covers the measured number.
By their numbers in this assay, from the lowest: compound 1; then compounds 2 and 3 (each within the scatter of the next).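

In this assay, putting 2-fluorophenyl in place of 4-bromophenyl on a carbon with a double bond to nitrogen gives a 1.0-fold higher number from compound 2 to compound 3 (0.00 log units; within the scatter), so the two compounds cannot be told apart in this test. For the compounds shown here, this is the first direct look at a change at this place, and it shows that this particular exchange of one halogen-bearing phenyl group for another, with the same count of heavy atoms, leaves no readable mark on the result, although a single pair cannot show how other groups would behave here. Nothing measured here explains why the two compounds match, so the result can only be recorded as an observation.

The exchange alters both the halogen and the ring number in the group's name, which means the compounds shown cannot separate those two features, and 4-fluorophenyl or 2-bromophenyl would be needed to pull them apart. From the compounds shown here alone, it also remains open whether this place responds to anything beyond these two groups, such as plain phenyl without a halogen or a phenyl ring carrying an amine or a carboxylic acid.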